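Swapping Chloro for Bromo on the Shared Core

The source may hold more compounds than are shown below. What is called first, only, known or untested is meant among the compounds shown, and "the series" means these compounds.

Measured compounds:
compound 1 `N#Cc1c(-c2ccccc2Cl)c(C#N)c(=O)n(/N=C/c2cn(-c3ccccc3)nc2-c2ccccc2)c1N`: 84 ug/mL
compound 2 `COc1ccc(-c2c(C#N)c(N)n(/N=C/c3cn(-c4ccccc4)nc3-c3ccccc3)c(=O)c2C#N)cc1`: 50 ug/mL

In an ADME assay on NIH3T3 cells (Mus musculus) for cytotoxicity, read by MTT assay (on this read-out lower numbers stand for stronger inhibition and higher numbers for weaker inhibition), compound 1 gives 84 ug/mL, the highest of the two numbers shown. Among the measured compounds shown here, compound 2 gives 50 ug/mL, and the only measured step, a 1.7-fold lower number from compound 1 to compound 2 (0.23 log units; within the scatter), lies within the scatter, so the two compounds cannot be told apart on this read-out.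

Compound 3 `N#Cc1c(-c2ccccc2Br)c(C#N)c(=O)n(/N=C/c2cn(-c3ccccc3)nc2-c2ccccc2)c1N` differs from compound 1 in one place: bromo in place of chloro on an aromatic carbon. For the measured compounds named here, no measured step shows this particular exchange. Going by the values given here, the single step available, a 1.7-fold lower number from compound 1 to compound 2 (0.23 log units; within the scatter), replaces the whole group at the same place and still produced no change beyond the scatter, which gives no reason to expect a smaller exchange of one halogen for another to move the number further. The step of a 1.1-fold lower number from compound 1 to compound 3 (0.02 log units; within the scatter) is therefore estimated to stay within the scatter, in no particular direction. Compound 3 is expected to give 80 ug/mL, with a range from 40 ug/mL to 160 ug/mL.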

Compound 3, half-maximal inhibitory concentration: 174 ug/mL
Estimate against measurement, compound 3: 2.2-fold (0.34 log units) below; measured number outside the range, above it.
By their numbers in this assay, from the lowest: compounds 2 and 1 (each within the scatter of the next); then compound 3.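

In this assay, among the compounds shown here, this place on the aromatic ring turns out to respond to the exchange of one halogen for another, with a 2.1-fold higher number from compound 1 to compound 3 (0.32 log units; beyond the scatter) standing as the first step here to pass beyond the scatter. The earlier step, a 1.7-fold lower number from compound 1 to compound 2 (0.23 log units; within the scatter), could not show that this place responds at all. With a 3.5-fold higher number from compound 2 to compound 3 (0.54 log units; beyond the scatter) as well, compound 3 stands clear of both other compounds and shows the weakest inhibition of the three, so on this read-out the 2-bromophenyl group separates from the 2-chlorophenyl and 4-methoxyphenyl groups.

On these data alone, whether a fluoro group, an amine or a carboxylic acid at this same place would raise the number further or bring it back down remains open. Nothing measured on these compounds gives a reason why bromo and chloro differ here.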